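Compound 4: nitro in place of methoxy

This account rests on a few compounds, and the source may have more. Where it says the series, first, only, none or still open, it means among the compounds named here.

In an ADME assay on J774.A1 cells (Mus musculus) for cytotoxicity, read by MTT assay, with a stated time of 48 h (on this read-out higher numbers stand for lower toxicity in this test and lower numbers for higher toxicity in this test), compound 1 (`C/C(=C\c1ccccc1)C(=O)/C=C/c1ccc([N+](=O)[O-])cc1`) gives 26000 nM as its value, compound 2 (`COc1ccc(/C=C(\C)C(=O)/C=C/c2ccc([N+](=O)[O-])cc2)cc1`) gives 30000 nM and compound 3 (`COc1ccc(/C=C/C(=O)/C(C)=C/c2ccc([N+](=O)[O-])cc2)cc1`) gives 36600 nM on the same read-out. Compound 3 therefore stands with the other two. Its gaps to both lie within the scatter, so these numbers do not separate the three compounds.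

Compound 4 (`C/C(=C\c1ccc([N+](=O)[O-])cc1)C(=O)/C=C/c1ccc([N+](=O)[O-])cc1`) has not yet been measured. It differs from compound 3 by nitro in place of methoxy on an aromatic carbon, para to a large group (nitro in place of methoxy on an aromatic carbon). For the measured compounds named here, no measured step makes this exchange. The closest evidence is a 1.2-fold higher number from compound 1 to compound 2 (0.06 log units; within the scatter) for methoxy in place of hydrogen on an aromatic carbon, and that step lies within the scatter. It concerns methoxy only and says nothing direct about nitro entering, so the support is thin.

No step beyond the scatter is therefore expected in this assay for this exchange. The expected step of a 1.2-fold lower number from compound 3 to compound 4 (0.09 log units; within the scatter) stays within the scatter, and the data give no firm direction for it. For compound 4 the estimated value is 30000 nM with an expected range from 13000 nM to 65000 nM on this read-out.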

Compound 4, half-maximal cytotoxic concentration: 43000 nM
The estimate for compound 4 lay 1.4-fold (0.16 log units) below the measured number; low and high end bracket the measured number.
By their numbers in this assay, from the lowest: compounds 1, 2, 3 and 4 (each within the scatter of the next).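

In this assay, nitro now joins hydrogen and methoxy on this aromatic carbon, para to a large group, and the new exchanges give a 1.2-fold higher number from compound 3 to compound 4 (0.07 log units; within the scatter) and a 1.4-fold higher number from compound 2 to compound 4 (0.16 log units; within the scatter) for nitro in place of methoxy, along with a 1.7-fold higher number from compound 1 to compound 4 (0.22 log units; within the scatter) for nitro in place of hydrogen. The earlier compounds shown here covered only methoxy in place of hydrogen at this place, whereas these steps show that a second group, with three heavy atoms and two hydrogen-bond acceptors, also leaves the number within the scatter of the other three compounds, so across the four compounds this read-out does not separate hydrogen, methoxy and nitro here. No measured evidence is at hand that would explain this flat picture.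

From the compounds shown here alone, whether an amine or a carboxylic acid on this aromatic carbon would give a step beyond the scatter stays open, and the same holds for a longer chain such as butoxy in place of methoxy. Also open is whether any exchange at this place can move the number clearly in this test, since every step shown so far remains within the scatter.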